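From 2-cyanobenzyl to 2-chlorobenzyl at the assay limit

The compounds below may be only part of what the source reports. "The series", "measured", "known", "first", "only" and "open" are said of these compounds alone.

Compound 1 `CSCC[C@H](NC(=O)c1ccc(NCc2cncn2Cc2ccccc2C#N)cc1-c1ccccc1)C(=O)O` is the starting point for this step. In a functional assay on NIH3T3 cells (Mus musculus) (on this read-out lower numbers stand for an effect already at smaller amounts and higher numbers for an effect only at larger amounts of compound), compound 1 gives > 10 uM, which is a limit and not a number. Compound 2 `COC(=O)[C@H](CCSC)NC(=O)c1ccc(NCc2cncn2Cc2ccc(Cl)cc2)cc1-c1ccccc1` gives > 10 uM in this assay, and this too is a limit. Compound 1 and compound 2 therefore both stand at the limit of > 10 uM in this assay, at which 2 of the 2 values shown sit, and neither has a numerical value to work from.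

Compound 3 `CSCC[C@H](NC(=O)c1ccc(NCc2cncn2Cc2ccccc2Cl)cc1-c1ccccc1)C(=O)O` keeps the core of compound 1 but carries chloro in place of cyano on an aromatic carbon, ortho to a large group, so that 2-cyanobenzyl becomes 2-chlorobenzyl: chloro in place of cyano on an aromatic carbon. Among the measured compounds shown here, no measured step shows what this exchange does. In this assay no shift beyond the scatter is expected in either direction, and a further result reported only as a limit is the likeliest outcome. The estimated step that the limit leaves unreadable from compound 1 to compound 3 is accordingly small. Compound 3 is estimated at 15 uM, within an expected range of 5 uM to 40 uM.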

Compound 3, concentration for half-maximal effect: > 10 uM
Compound 3 gave a limit, no number (the forecaster's own chance of this, stated with the estimate: 80%); the middle value is on the limit's open side.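

In this assay compound 3 gives > 10 uM, which is a limit and not a number. Among the compounds shown here, no step from compound 1 to compound 3 can be read, as both stand at the same limit: the limit of > 10 uM in this assay, at which 3 of the 3 values shown sit.

As far as these compounds go, what chloro in place of cyano does to the effect, and how these compounds rank on this read-out, stays open.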